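Ring-nitrogen substituent change from compound 3 to compound 4

The compounds below may be only part of what the source reports. "The series", "measured", "known", "first", "only" and "open" are said of these compounds alone.

Measured so far:
compound 1 `c1cc(CN2CCN(CCCc3c[nH]c4ccc(-n5cnnc5)cc34)CC2)ccn1`: 1 nM
compound 2 `c1c[nH]c(CN2CCN(CCCc3c[nH]c4ccc(-n5cnnc5)cc34)CC2)n1`: 2 nM
compound 3 `CC(=O)Nc1ccc(CN2CCN(CCCc3c[nH]c4ccc(-n5cnnc5)cc34)CC2)cc1`: 6.1 nM

In a functional assay on CHO cells for activation of 5-hydroxytryptamine receptor 1D (Homo sapiens), read by GTPgammaS binding (a lower number here means that less compound is needed, a higher number that more compound is needed for the effect), compound 3 gives the highest of the three numbers; the steps of a 6.1-fold higher number from compound 1 to compound 3 (0.79 log units; beyond the scatter) and a 3.1-fold higher number from compound 2 to compound 3 (0.48 log units; beyond the scatter) are modest but beyond the scatter, while a 2.0-fold higher number from compound 1 to compound 2 (0.30 log units; within the scatter) lies within it. Compound 4 `NC(=O)C(c1ccccc1)N1CCN(CCCc2c[nH]c3ccc(-n4cnnc4)cc23)CC1` differs from compound 3 by carbamoyl(phenyl)methyl in place of 4-acetamidobenzyl on an amine nitrogen in a ring. Within the data shown here, no measured step covers this particular exchange; the three measured steps only show that swapping the group on that ring nitrogen moves the number modestly at most. A small shift, direction uncertain, is therefore expected, a 1.3-fold higher number from compound 3 to compound 4 (0.12 log units; within the scatter). Compound 4 is estimated at 8 nM, with a range of 2.5 nM to 25 nM.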

Compound 4, half-maximal effective concentration: 0.2 nM
For compound 4 the middle estimate is 40-fold (1.60 log units) above the measured one; the whole stated range lies above it.
By their numbers in this assay, from the lowest: compound 4; then compounds 1 and 2 (each within the scatter of the next); then compound 3.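

In this assay the number falls on moving to carbamoyl(phenyl)methyl on the ring nitrogen: a 31-fold lower number from compound 3 to compound 4 (1.48 log units; beyond the scatter) and a 10-fold lower number from compound 2 to compound 4 (1.00 log units; beyond the scatter) and also a 5.0-fold lower number from compound 1 to compound 4 (0.70 log units; beyond the scatter) are all beyond the scatter. This position can therefore move the number further than the steps among compounds 1, 2 and 3 showed, and a group on that nitrogen can give a lower number than the (pyridin-4-yl)methyl of compound 1. No measurement shown accounts for the size of this drop.

As far as these compounds go, whether the carbamoyl or the phenyl matters more stays open. A plain benzyl group, or a carboxylic acid in place of the carbamoyl, would help separate the two.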